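A few compounds are considered here, and "the series" means these few. Any claim that something is new, unique, unknown or untested is made for them only; others in the source may bear on it.

Measured compounds and their numbers in a functional assay on MCF7 cells (Homo sapiens) for cytotoxicity, read by WST assay, with a stated time of 72 h; on this read-out higher numbers stand for weaker inhibition and lower numbers for stronger inhibition:
- compound 1 `O=C1Nc2c(ccc(F)c2F)C1(c1ccccc1)c1ccc(O)cc1` gives 7.1 nM
- compound 2 `O=C1Nc2c(ccc(F)c2F)C1(c1ccc(O)cc1)c1ccc(F)cc1` gives 2.6 nM
- compound 3 `O=C1Nc2c(ccc(F)c2F)C1(c1ccc(O)cc1)c1cccnc1` gives 63 nM

Among these three, compound 1 holds the second highest number in this assay: compound 2 sits closest, with a 2.7-fold lower number from compound 1 to compound 2 (0.44 log units; beyond the scatter), while compound 3 lies furthest away, with an 8.9-fold higher number from compound 1 to compound 3 (0.95 log units; beyond the scatter). Compound 4 `CCCCCC1(c2ccc(O)cc2)C(=O)Nc2c1ccc(F)c2F` has not yet been measured. It differs from compound 1 in one place: pentyl in place of phenyl on a saturated ring carbon.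

The steps that speak to a change at this same saturated ring carbon are those leading to compound 3. Replacing phenyl there gave an 8.9-fold higher number from compound 1 to compound 3 (0.95 log units; beyond the scatter), and replacing 4-fluorophenyl gave a 24-fold higher number from compound 2 to compound 3 (1.38 log units; beyond the scatter); both point in the same direction, toward weaker inhibition, and both lie beyond the scatter. The step from compound 1 to compound 2 changes only a substituent on the ring that leaves, so it says little here. Swapping the ring for a pentyl chain is a larger departure than either measured change, so a step toward a higher number is expected, likely at least as large as the one to compound 3. Compound 4 is therefore estimated at 90 nM, with a range from 15 nM to 600 nM, which would mean an expected step of a 13-fold higher number from compound 1 to compound 4 (1.10 log units; beyond the scatter).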

Compound 4, half-maximal inhibitory concentration: 96 nM
Compound 4: middle estimate off by 1.1-fold (0.03 log units), on the low side; low and high end bracket the measured number.
By their numbers in this assay, from the lowest: compound 2; then compound 1; then compounds 3 and 4 (each within the scatter of the next).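

In this assay the new result shows that an aromatic ring at this saturated ring carbon can be replaced by a chain with no ring, but only at a large cost against the two benzene-bearing compounds (a 14-fold higher number from compound 1 to compound 4 (1.13 log units; beyond the scatter); a 37-fold higher number from compound 2 to compound 4 (1.57 log units; beyond the scatter)). The pentyl chain and the pyridin-3-yl ring cannot be told apart here (a 1.5-fold higher number from compound 3 to compound 4 (0.18 log units; within the scatter)), so among these compounds, having an aromatic ring at this carbon does not by itself keep the number low: compound 3 has one, yet lies within the scatter of compound 4, which has none. No measurement given here explains these differences.

A shorter chain such as ethyl or a longer one such as octyl would show whether chain length matters at this carbon, and a saturated ring such as cyclohexyl would separate the effect of having a ring from that of having an aromatic one. On these data alone, a pentyl chain ending in an amine or a carboxylic acid also remains open.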